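The source may report more compounds than this note shows. Statements on the series, on what has been measured and on what is new or still open speak of the compounds shown alone.

In a functional assay on MCF7 cells (Homo sapiens) for cytotoxicity, read by MTT assay, with a stated time of 72 h (on this read-out higher numbers stand for weaker inhibition and lower numbers for stronger inhibition), compound 3 (`COc1ncc(-c2ccc3nc(NC(=O)NCC(=O)N4CCOCC4)nn3c2)cc1NS(=O)(=O)c1ccc(F)cc1`) gives 630 nM and compound 1 (`COc1ncc(-c2ccc3nc(NC(=O)NCCN4CCCC4)nn3c2)cc1NS(=O)(=O)c1ccc(F)cc1`) gives 380 nM within the scatter of each other, while compound 2 (`COc1ncc(-c2ccc3nc(NC(=O)NC4CC4)nn3c2)cc1NS(=O)(=O)c1ccc(F)cc1`) gives 300 nM and a 2.1-fold higher number from compound 2 to compound 3 (0.32 log units; beyond the scatter) stands as a modest step. Going to compound 4 (`COc1ncc(-c2ccc3nc(NC(=O)NCCN4CCN(C)CC4)nn3c2)cc1NS(=O)(=O)c1ccc(F)cc1`) the change is (4-methylpiperazin-1-yl)methyl in place of (morpholin-4-yl)carbonyl on a saturated chain carbon bound to an amide-type nitrogen with (4-methylpiperazin-1-yl)methyl in place of (morpholin-4-yl)carbonyl on a saturated chain carbon bound to an amide-type nitrogen. The closest measured step at that place is a 1.7-fold higher number from compound 1 to compound 3 (0.22 log units; within the scatter) and it runs the opposite way, from a (pyrrolidin-1-yl)methyl group to the same (morpholin-4-yl)carbonyl. A small fall in the number is therefore expected in this assay but nothing beyond the scatter. The expected change is a 1.6-fold lower number from compound 3 to compound 4 (0.20 log units; within the scatter) on this estimate. For compound 4 the estimated value is 400 nM with an expected range of 170 nM to 950 nM in this read-out.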

Compound 4, half-maximal inhibitory concentration: 500 nM
Estimate against measurement, compound 4: 1.3-fold (0.10 log units) below; the measured number falls inside the stated range.
By their numbers in this assay, from the lowest: compounds 2, 1, 4 and 3 (each within the scatter of the next, the first and the last beyond it).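

In this assay, a second basic-free label cannot be applied, but the 2-(4-methylpiperazin-1-yl)ethyl group on the amide-type nitrogen does not separate from any of the three earlier groups (a 1.3-fold lower number from compound 3 to compound 4 (0.10 log units; within the scatter); a 1.3-fold higher number from compound 1 to compound 4 (0.12 log units; within the scatter); a 1.7-fold higher number from compound 2 to compound 4 (0.22 log units; within the scatter)). Swapping pyrrolidin-1-yl for 4-methylpiperazin-1-yl therefore gives no readable change at this place, and the one step beyond the scatter remains the modest step between compound 2 and compound 3. Nothing at hand explains these readings.

As far as these compounds go, whether a dimethylamino group or a carboxylic acid at the end of this chain, or a longer chain, would move the number beyond the scatter stays open.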